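The source may report more compounds than this note shows. Statements on the series, on what has been measured and on what is new or still open speak of the compounds shown alone.

Measured so far:
compound 1, `COc1ccc2ccc(=O)oc2c1C1=NN(c2ccccc2)C(c2ccc(SC)cc2)C1`: 78 nM
compound 2, `COc1ccc2ccc(=O)oc2c1C1=NN(C(C)=O)C(c2ccc(SC)cc2)C1`: 42 nM

For the measured compounds named here, in a functional assay on HepG2 cells (Homo sapiens) for cytotoxicity, read by MTT assay, with a stated time of 72 h (a lower number here means a stronger inhibitor, a higher number a weaker inhibitor), compound 1 stands at the higher of the two numbers, yet its only neighbour, compound 2, differs from it solely at the ring nitrogen, and that step, a 1.9-fold lower number from compound 1 to compound 2 (0.27 log units; within the scatter), lies within the scatter, so the two cannot be ranked against each other.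

Compound 3, `COc1ccc2ccc(=O)oc2c1C1=NN(c2ccccc2)C(c2ccc(C(F)(F)F)cc2)C1`, changes compound 1 at a different place: trifluoromethyl in place of methylsulfanyl on an aromatic carbon. Going by the values given here, the one step measured so far concerns the ring nitrogen and leaves this aromatic position untouched, so it does not bear on the change. Among the compounds with values here, with no measured step at this place, no direction beyond the scatter can be read from the data, and the expectation rests on compound 1 alone.

Compound 3 is therefore expected to give about 80 nM, with a range from 25 nM to 250 nM. The expected step of a 1.0-fold higher number from compound 1 to compound 3 (0.01 log units; within the scatter) is meant only as an estimate that stays close to the starting point.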

Compound 3, half-maximal inhibitory concentration: 38 nM
Compound 3: the middle estimate sits 2.1-fold (0.32 log units) above what was measured, within the range that was stated.
By their numbers in this assay, from the lowest: compounds 3, 2 and 1 (each within the scatter of the next, the first and the last beyond it).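

In this assay, replacing methylsulfanyl with trifluoromethyl on the aromatic carbon gives a 2.1-fold lower number from compound 1 to compound 3 (0.31 log units; beyond the scatter) and thus shows that this position can shift the number beyond the usual scatter, though only modestly. The earlier step at the ring nitrogen stayed within the scatter, so it gave no measurable sign that a change in the core of compound 1 could move the result. Nothing available here explains why this swap has this effect.

The compounds shown leave open whether an amine, a carboxylic acid or a longer chain at the same aromatic carbon would move the number further, or in the opposite direction. They also leave open whether trifluoromethyl would have a similar effect with acetyl rather than phenyl on the ring nitrogen.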